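A few compounds are considered here, and "the series" means these few. Any claim that something is new, unique, unknown or untested is made for them only; others in the source may bear on it.

Three compounds share one core and differ only in the aryl group attached to the carbonyl carbon of an amide. Compound 1 `COc1ccc(C(=O)Nc2cccc(-c3oc4cc(-c5ccc(F)cc5)ccc4c(=O)c3O)c2)cc1` gives 8700 nM in a functional assay on A549 cells (Homo sapiens) for antiproliferative activity, read by CCK-8 assay, with a stated time of 72 h; on this read-out higher numbers stand for weaker inhibition and lower numbers for stronger inhibition. Compound 2 `Cc1ccccc1C(=O)Nc1cccc(-c2oc3cc(-c4ccc(F)cc4)ccc3c(=O)c2O)c1` gives 17600 nM in this assay. Compound 3 `COc1cccc(C(=O)Nc2cccc(-c3oc4cc(-c5ccc(F)cc5)ccc4c(=O)c3O)c2)c1` gives 10800 nM in this assay, which places it second highest of the three numbers, nearest to compound 1 and furthest from compound 2, though both of those gaps lie within the scatter. The measured steps show how much this aryl group matters: a 2.0-fold higher number from compound 1 to compound 2 (0.31 log units; beyond the scatter), a 1.2-fold higher number from compound 1 to compound 3 (0.09 log units; within the scatter) and a 1.6-fold lower number from compound 2 to compound 3 (0.21 log units; within the scatter). Only the first of these reaches beyond the scatter, and it is described as modest.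

Compound 4 `Cc1cc(C(=O)Nc2cccc(-c3oc4cc(-c5ccc(F)cc5)ccc4c(=O)c3O)c2)ccc1F` has not yet been measured. It differs from compound 3 in one place: 4-fluoro-3-methylphenyl in place of 3-methoxyphenyl on a carbonyl carbon. The change again swaps one substituted aryl group for another of the same size on the same carbonyl carbon, so the measured steps are the relevant guide. Because a 2.0-fold higher number from compound 1 to compound 2 (0.31 log units; beyond the scatter) is the largest shift seen and is only modest, a step of at most similar size is expected, with no clear direction. Compound 4 is therefore expected to give about 11000 nM in this assay, between 5000 nM and 25000 nM. The expected shift, a 1.0-fold higher number from compound 3 to compound 4 (0.01 log units; within the scatter), is estimated to fall within the scatter.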

Compound 4, half-maximal inhibitory concentration: 11500 nM
For compound 4 the middle estimate is 1.0-fold (0.02 log units) below the measured one, and the stated range covers the measured number.
By their numbers in this assay, from the lowest: compounds 1, 3, 4 and 2 (each within the scatter of the next, the first and the last beyond it).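

Swapping the 3-methoxyphenyl for 4-fluoro-3-methylphenyl exchanges an aryl group with one hydrogen-bond acceptor for one with none, and brings in fluorine and a methyl group at the same heavy-atom count, yet this assay records only a 1.1-fold higher number from compound 3 to compound 4 (0.03 log units; within the scatter). The new aryl group also gives a 1.5-fold lower number from compound 2 to compound 4 (0.18 log units; within the scatter) and a 1.3-fold higher number from compound 1 to compound 4 (0.12 log units; within the scatter), so it stands within the scatter of compound 1 and compound 2, even though those two lie beyond the scatter of each other. In this small set, then, an aryl group with two substituents and no oxygen on this carbonyl carbon still gives a number in the same range as the methoxyphenyl groups, and no supporting measurement is available to explain this result.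

From the compounds shown here alone, all four compounds carry a substituted phenyl on this carbonyl carbon, so it remains open whether an aliphatic amine, a carboxylic acid or a longer alkyl chain there would move the number much further. Going by these compounds, it also remains open whether changing the rest of the shared core would matter more than changing this aryl group.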